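Swapping a carboxythiophene for a carboxymethoxyphenyl on the core

This account rests on a few compounds, and the source may have more. Where it says the series, first, only, none or still open, it means among the compounds named here.

Compound 1, `O=C(O)c1ccc(CN2CCC[C@H](OCc3cc(Cl)cc(Cl)c3)[C@@H]2c2ccccc2)s1`: 76000 nM in an assay on isolated protein for activation of cGMP-dependent protein kinase 1 (Homo sapiens), read by ADP-Glo, with stated times of 120 min and 40 min; on this read-out lower numbers stand for an effect already at smaller amounts and higher numbers for an effect only at larger amounts of compound
Compound 2, `OC[C@@H](O[C@H]1CCCN(Cc2cccc3nonc23)[C@H]1c1ccccc1)c1cc(Cl)cc(Cl)c1`: 8000 nM in this assay

For the measured compounds named here, only these two compounds have been measured in this assay so far. Compound 1 stands at the highest of the two numbers; its nearest neighbour, compound 2, shows a clearly lower number, and that gap lies beyond the usual scatter. Going by the values given here, the two compounds differ in several places at once, so no single step between them can be read off.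

Compound 3, `COc1cc(C(=O)O)ccc1CN1CCC[C@H](OCc2cc(Cl)cc(Cl)c2)[C@@H]1c1ccccc1`, is the next candidate. It differs from compound 1 in one place: 4-carboxy-2-methoxyphenyl in place of 5-carboxythiophen-2-yl on a saturated chain carbon bound to an amine nitrogen in a ring. Among the compounds with values here, no measured pair shows the effect of such an exchange, so the expectation for compound 3 rests on compound 1 alone. The step of a 1.7-fold lower number from compound 1 to compound 3 (0.23 log units; within the scatter) is expected to be small and most likely within the scatter, with a slight lean towards a lower number. Compound 3 is therefore estimated at 45000 nM, within a range from 12000 nM to 160000 nM.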

Compound 3, half-maximal effective concentration: 62000 nM
Compound 3: the middle estimate sits 1.4-fold (0.14 log units) below what was measured, within the range that was stated.
By their numbers in this assay, from the lowest: compound 2; then compounds 3 and 1 (each within the scatter of the next).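

At this place, on a saturated chain carbon bound to an amine nitrogen in a ring, the exchange of one carboxy-bearing aromatic ring for another gives a 1.2-fold lower number from compound 1 to compound 3 (0.09 log units; within the scatter) in this assay and so leaves the read-out unchanged within the scatter. The step therefore shows that this exchange, with its larger group of 11 heavy atoms in place of 8, is tolerated without any measurable gain or loss. No measurement at hand explains why the two groups behave alike.

As far as these compounds go, the exchange changes the ring and adds a methoxy group in a single step, so the share of each remains unknown, and the two could even offset each other. Both groups also carry a carboxylic acid, which leaves open how the number would respond to a primary amide or a tetrazole in its place.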